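Swapping a Hydroxy for a Triethylpyrazole on Compound 3

This account rests on a few compounds, and the source may have more. Where it says the series, first, only, none or still open, it means among the compounds named here.

Of the compounds shown here, three sharing one core have been measured in an assay on HEK293 cells for displacement of a labelled ligand from NPC1-like intracellular cholesterol transporter 1 (Homo sapiens); on this read-out lower numbers stand for stronger inhibition and higher numbers for weaker inhibition. Compound 1 `CC(C)(C)OC(=O)NCCNC(=O)CN1CN(c2ccccc2)C2(CCN(C(=O)c3ccc(C(C)(C)C)cc3)CC2)C1=O` gives 10900 nM, compound 2 `CC(C)(C)c1ccc(C(=O)N2CCC3(CC2)C(=O)N(CC(=O)N2CCCCC2CCO)CN3c2ccccc2)cc1` gives 6100 nM, and compound 3 `CC(C)(C)c1ccc(C(=O)N2CCC3(CC2)C(=O)N(CC(=O)N2CCC(O)CC2)CN3c2ccccc2)cc1` gives 4700 nM. Compound 3 sits at the low end of these numbers: the step of a 2.3-fold lower number from compound 1 to compound 3 (0.37 log units; beyond the scatter) clears the scatter, whereas a 1.3-fold lower number from compound 2 to compound 3 (0.11 log units; within the scatter) does not. Both of those steps alter the group on the amide carbonyl. Compound 4 `CCc1nn(CC)c(C2CCN(C(=O)CN3CN(c4ccccc4)C4(CCN(C(=O)c5ccc(C(C)(C)C)cc5)CC4)C3=O)CC2)c1CC` changes a different spot: 1,3,4-triethyl-1H-pyrazol-5-yl in place of hydroxy on a saturated ring carbon. Within the data shown here, no measured step touches that ring carbon, so this change has no direct precedent, and the measured steps were all small. Compound 4 is therefore expected to show a step of similar size, a 1.3-fold lower number from compound 3 to compound 4 (0.13 log units; within the scatter). Compound 4 is estimated at 3500 nM, in the range 1000 nM to 12000 nM.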

Compound 4, half-maximal inhibitory concentration: 4600 nM
For compound 4 the middle estimate is 1.3-fold (0.12 log units) below the measured one, and the stated range covers the measured number.
By their numbers in this assay, from the lowest: compounds 4, 3, 2 and 1 (each within the scatter of the next, the first and the last beyond it).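

Putting 1,3,4-triethyl-1H-pyrazol-5-yl in place of hydroxy on this saturated ring carbon gives a 1.0-fold lower number from compound 3 to compound 4 (0.01 log units; within the scatter) in this assay. The position therefore takes a group of 11 heavy atoms with a five-membered aromatic ring, and loses the hydroxy's hydrogen-bond donor, with no step beyond the scatter. Nothing shown explains why the number holds steady. Going by these compounds, whether an amine or a carboxylic acid on this ring carbon would shift the number remains open. So does whether a pyrazole without the three ethyl groups would read the same.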